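Lengthening the chain on compound 2

The source may report more compounds than this note shows. Statements on the series, on what has been measured and on what is new or still open speak of the compounds shown alone.

Measured in a functional assay on MDA-MB-231 cells (Homo sapiens) for antiproliferative activity, with a stated time of 4 days; a higher number here means a weaker inhibitor, a lower number a stronger inhibitor:
- compound 1 `CCCCCCc1ccc2[nH]c(-c3ccc(OC)cc3)c(C=O)c2c1` gives 7.4 nM
- compound 2 `CCCCCc1ccc2[nH]c(-c3ccc(C(F)(F)F)cc3)c(C=O)c2c1` gives 42 nM

Compound 2 holds the higher of the two numbers, and its gap to compound 1 lies beyond the usual scatter. Compound 3 `CCCCCCc1ccc2[nH]c(-c3ccc(C(F)(F)F)cc3)c(C=O)c2c1` extends the chain of compound 2 by methyl in place of hydrogen on a saturated chain carbon, five bonds along the chain from an aromatic carbon. Among the measured compounds shown here, no measured pair isolates this change, so the evidence is indirect. The longer chain of compound 3 is shared by compound 1, and compound 1 gives 7.4 nM, but it also differs elsewhere. A small move to a lower number in this assay is expected, possibly none beyond the scatter. The expected change is a 1.5-fold lower number from compound 2 to compound 3 (0.18 log units; within the scatter). For compound 3 the estimated value is 28 nM, within an expected range of 10 nM to 75 nM.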

Compound 3, half-maximal inhibitory concentration: 43 nM
Compound 3: the middle estimate sits 1.5-fold (0.19 log units) below what was measured; the measured number falls inside the stated range.
By their numbers in this assay, from the lowest: compound 1; then compounds 2 and 3 (each within the scatter of the next).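

In this assay, methyl in place of hydrogen on a saturated chain carbon, five bonds along the chain from an aromatic carbon, gives a 1.0-fold higher number from compound 2 to compound 3 (0.01 log units; within the scatter) and so shows no change at this position with trifluoromethyl present. With the longer chain held constant, trifluoromethyl in place of methoxy on an aromatic carbon gives a 5.8-fold higher number from compound 1 to compound 3 (0.76 log units; beyond the scatter) and now isolates that exchange as a step beyond the scatter. No measurement on hand offers an explanation for either step.

As far as these compounds go, whether the same chain step reads alike with methoxy in place of trifluoromethyl stays open. So does the outcome of a longer chain, or of an amine or a carboxylic acid in place of this methyl.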